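Working notes: from compound 3 to compound 4

A few compounds are considered here, and "the series" means these few. Any claim that something is new, unique, unknown or untested is made for them only; others in the source may bear on it.

- compound 1 `Cc1cccc(NC(=O)c2nn(C)c(-c3ccc(F)cc3F)c2C)n1` 0.633 h
- compound 2 `Cc1cccc(NC(=O)c2nn(C)c(-c3cc(F)cc(F)c3)c2C)n1` 0.3 h
- compound 3 `Cc1nc(C(=O)Nc2cccc(F)n2)c(C)n1-c1ccc(F)cc1` 0.617 h

In an ADME assay on microsomes from liver (Mus musculus) for metabolic stability (on this read-out lower numbers stand for a shorter-lived compound and higher numbers for a longer-lived compound), compound 3 (0.617 h) sits level, within the scatter, with compound 1 (0.633 h). Compound 2 (0.3 h) gives the lowest number of the three, beyond the scatter from both of the others.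

Compound 4 `Cc1nc(NC(=O)c2nc(C)n(-c3ccc(F)cc3)c2C)ccc1F` keeps the core of compound 3 and alters one group (5-fluoro-6-methylpyridin-2-yl in place of 6-fluoropyridin-2-yl on an amide-type nitrogen). Here 5-fluoro-6-methylpyridin-2-yl stands in place of 6-fluoropyridin-2-yl on an amide-type nitrogen.

For the measured compounds named here, only one measured step is available (a 2.1-fold lower number from compound 1 to compound 2 (0.32 log units; beyond the scatter)). It exchanges 2,4-difluorophenyl for 3,5-difluorophenyl on an aromatic carbon, so it concerns a different group from the one changing here. It is a modest step and offers only a rough guide to size. Going by the values given here, no measured pair tests the exchange on the amide-type nitrogen, and the data therefore give no direction for it.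

In this assay the expected step stays within the scatter, with no firm direction (a 1.1-fold lower number from compound 3 to compound 4 (0.05 log units; within the scatter)). Compound 4 is estimated at 0.55 h, with an expected range from 0.25 h to 1.1 h.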

Compound 4, half-life: 1.43 h
Compound 4: middle estimate off by 2.6-fold (0.41 log units), on the low side; the whole stated range lies below it.
By their numbers in this assay, from the lowest: compound 2; then compounds 3 and 1 (each within the scatter of the next); then compound 4.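

In this assay, for the compounds shown here, the exchange of 6-fluoropyridin-2-yl for 5-fluoro-6-methylpyridin-2-yl on the amide-type nitrogen gives a 2.3-fold higher number from compound 3 to compound 4 (0.37 log units; beyond the scatter), the first measured step at this place. The earlier pair, with a 2.1-fold lower number from compound 1 to compound 2 (0.32 log units; beyond the scatter), only tested a change on an aromatic carbon, so the new step adds that the group on the amide-type nitrogen can also move the half-life beyond the scatter, here towards a longer-lived compound. This rests on a single pair on the core of compound 3, and nothing at hand bears on why the number rises.

The exchange changes the fluorine placement and adds a methyl group in one step, so the compounds shown do not divide the rise between those two parts, and they do not show whether the same exchange holds on the core of compound 1. From the compounds shown here alone, it also remains open how this assay would respond to a methoxy group or an ethyl chain on the pyridine ring in place of that methyl group.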